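This account rests on a few compounds, and the source may have more. Where it says the series, first, only, none or still open, it means among the compounds named here.

Among the compounds with values here, in an ADME assay on THP-1 cells (Homo sapiens) for cytotoxicity, read by resazurin assay, with a stated time of 72 h (on this read-out lower numbers stand for higher toxicity in this test and higher numbers for lower toxicity in this test), compound 2 `C#CCOc1ccc(C(=O)/C=C/c2cccnc2)c(O)c1` gives 25000 nM, the lower of the two numbers measured so far, while compound 1 `CC(C)=CCOc1ccc(C(=O)/C=C/c2cccnc2)c(O)c1` gives 100000 nM. Compound 3 `C#CCOc1ccc(C(=O)/C=C/c2cccnc2)c(OC)c1` changes compound 2 in one place, hydroxy to methoxy: methyl in place of hydrogen on an oxygen on an aromatic ring. Within the data shown here, the only measured step, a 4.0-fold lower number from compound 1 to compound 2 (0.60 log units; beyond the scatter), involves a different group, so it gives no direction here and serves only as a rough guide to size. With no firm direction, the expected step is small and within the scatter, at a 1.2-fold higher number from compound 2 to compound 3 (0.08 log units; within the scatter). Compound 3 is estimated at 30000 nM, with an expected range of 9000 nM to 100000 nM.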

Compound 3, half-maximal cytotoxic concentration: 16000 nM
Estimate against measurement, compound 3: 1.9-fold (0.27 log units) above, within the range that was stated.
By their numbers in this assay, from the lowest: compounds 3 and 2 (each within the scatter of the next); then compound 1.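

Methyl in place of hydrogen on the oxygen on the aromatic ring, that is hydroxy to methoxy, is a change the earlier compounds did not cover. In this assay it gives a 1.6-fold lower number from compound 2 to compound 3 (0.19 log units; within the scatter), so this single pair shows no difference that can be told from the usual scatter of repeated measurements. Nothing available gives a reason for this result.

From the compounds shown here alone, whether a longer chain on that oxygen, or an amine in place of the hydroxy, would move the number beyond the scatter remains open. So does whether hydroxy to methoxy would read the same on compound 1.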